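This account rests on a few compounds, and the source may have more. Where it says the series, first, only, none or still open, it means among the compounds named here.

Three measured compounds and one not yet measured are compared in an ADME assay on MT4 cells (Homo sapiens) for cytotoxicity, read by MTT assay, with a stated time of 5 days; on this read-out higher numbers stand for lower toxicity in this test and lower numbers for higher toxicity in this test. Compound 1 `N#Cc1ccc(Nc2nccc(OCC(=O)Nc3ccc([N+](=O)[O-])cc3)n2)cc1` carries a 4-nitrophenyl group on an amide-type nitrogen. In this assay compound 1 gives only a limit, > 320000 nM. Compound 2 `N#Cc1ccc(Nc2nccc(OCC(=O)Nc3ccc(C#N)cc3F)n2)cc1` differs from compound 1 in one place: 4-cyano-2-fluorophenyl in place of 4-nitrophenyl on an amide-type nitrogen. In this assay compound 2 also gives only a limit, > 321000 nM. The step from compound 1 to compound 2 is a step that the two limits leave unreadable from compound 1 to compound 2, which cannot be read as a number due to the limit of > 320000 nM in this assay, at which 1 of the 3 values shown sits, and (the limit of > 321000 nM in this assay, at which 1 of the 3 values shown sits).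

Compound 3 `Cc1cnc(Nc2ccc(C#N)cc2)nc1OCC(=O)Nc1ccc([N+](=O)[O-])cc1` has a different core from compound 1; the difference is methyl in place of hydrogen on an aromatic carbon. In this assay, among the measured compounds shown here, compound 3 gives 66300 nM, the only number among the three. The step from compound 1 to compound 3 is an at least 4.8-fold lower number from compound 1 to compound 3 (0.68 log units; beyond the scatter), meaning higher toxicity on this read-out.

Compound 4 `Cc1cnc(Nc2ccc(C#N)cc2)nc1OCC(=O)Nc1ccc(C#N)cc1F` has not yet been measured in this assay. It differs from compound 3 in one place: 4-cyano-2-fluorophenyl in place of 4-nitrophenyl on an amide-type nitrogen. For the measured compounds named here, this is the same change as the one from compound 1 to compound 2, now made on the core of compound 3, and the place is the same word for word. Because the earlier step is a step that the two limits leave unreadable from compound 1 to compound 2, its size cannot guide the new one, so the expectation rests mainly on compound 3 at 66300 nM. For compound 4 the expected step is a 1.4-fold higher number from compound 3 to compound 4 (0.13 log units; within the scatter), a small one. Compound 4 is therefore expected to give about 90000 nM in this assay, with a likely range from 30000 nM to 320000 nM.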

Compound 4, half-maximal cytotoxic concentration: > 310000 nM
Compound 4: no number, only a limit; the forecaster's own chance of this, stated with the estimate: 25%; at least 3.4-fold (0.53 log units) between middle value and limit.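

In this assay compound 4 gives > 310000 nM, which is a limit of the assay and not a number. On the core of compound 3, putting 4-cyano-2-fluorophenyl in place of 4-nitrophenyl on the amide-type nitrogen gives an at least 4.6-fold higher number from compound 3 to compound 4 (0.66 log units; beyond the scatter), so on this core the change goes with lower toxicity in this test, and the limit leaves open how large the step really is. From the compounds shown here alone, the steps from compound 1 to compound 2 and from compound 2 to compound 4 cannot be read, so the data do not show that the change acts alike on the two cores, and the carry-over from one core to the other remains untested by any readable pair.

The compounds shown leave open which part of the new group goes with the step on the core of compound 3, since the nitrile and the fluorine enter together, and a plain 4-cyanophenyl group on the same nitrogen would separate them. They also leave open how other groups at this place would read on that core, for example a 4-aminophenyl group, which carries an amine where 4-nitrophenyl carries its nitro group.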